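This account rests on a few compounds, and the source may have more. Where it says the series, first, only, none or still open, it means among the compounds named here.

Measured compounds:
compound 1 `Cc1nnc(SCC(=O)c2ccc(Cl)cc2)n1N1C(=O)c2ccccc2C1=O` — > 200000 nM
compound 2 `C=CCSc1nnc(CC)n1N1C(=O)c2ccccc2C1=O` — > 200000 nM

Both compounds were tested in a functional assay on MKN-45 cells (Homo sapiens) for cytotoxicity, read by MTT assay, with a stated time of 48 h; on this read-out higher numbers stand for weaker inhibition and lower numbers for stronger inhibition. For compound 1 the value > 200000 nM is a limit of the assay rather than a number. For compound 2 the value > 200000 nM is likewise a limit. Compound 2 therefore stands where all shown values stand: the limit of > 200000 nM in this assay, at which 2 of the 2 values shown sit. For the measured compounds named here, no step between measured compounds is available, so the data give no measured step size to lean on.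

Compound 3 `CCOC(=O)CSc1nnc(CC)n1N1C(=O)c2ccccc2C1=O` has not yet been measured. It differs from compound 2 by ethoxycarbonyl in place of vinyl on a saturated chain carbon bound to a sulfur. With nothing measured to set a direction, the step from compound 2 to compound 3 is expected to be a number no higher from compound 2 to compound 3 (the limit leaves the size open), that is, none beyond the scatter. Compound 3 is accordingly expected to give about 200000 nM, with a range from 50000 nM to 400000 nM, most likely reported again only as a limit.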

Compound 3, half-maximal inhibitory concentration: > 200000 nM
Compound 3: only a limit was reported; the forecaster's own chance of this, stated with the estimate: 85%; the middle value sits exactly at the limit.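

For the compounds shown here, compound 2 and compound 3 are both reported only as limits in this assay, so no step between them can be read. The compounds shown leave open whether any change among them alters cytotoxicity, because all of them stand at one limit: the limit of > 200000 nM in this assay, at which 3 of the 3 values shown sit.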